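Swapping the Aryl Group on a Triazole Ring

The source may hold more compounds than are shown below. What is called first, only, known or untested is meant among the compounds shown, and "the series" means these compounds.

Compound 1 `Cc1ccc(-n2cc(-c3ccccc3NS(=O)(=O)c3c[nH]c(=O)[nH]c3=O)nn2)cc1` is tested in a functional assay on HepG2 cells (Homo sapiens) for antiproliferative activity, read by MTT assay, with a stated time of 24 h (a higher number here means a weaker inhibitor, a lower number a stronger inhibitor), where compound 1 gives 8350 nM. Compound 2 `O=c1[nH]cc(S(=O)(=O)Nc2ccccc2-c2cn(-c3ccccc3F)nn2)c(=O)[nH]1` differs from it by 2-fluorophenyl in place of 4-methylphenyl on an aromatic nitrogen, and in this assay compound 2 gives 12500 nM. That change gives a 1.5-fold higher number from compound 1 to compound 2 (0.18 log units; within the scatter). Compound 3 `Cc1ccc(-n2cc(-c3cccc(NS(=O)(=O)c4c[nH]c(=O)[nH]c4=O)c3)nn2)cc1` has the same atoms as compound 1 joined differently, and the difference between the two cores is not broken down here. In this assay compound 3 reaches only a limit of the assay, > 20000 nM. This is the limit of > 20000 nM in this assay, at which 1 of the 3 values shown sits. Compound 4 `O=c1[nH]cc(S(=O)(=O)Nc2cccc(-c3cn(-c4ccccc4F)nn3)c2)c(=O)[nH]1` has not yet been measured; it differs from compound 3 by 2-fluorophenyl in place of 4-methylphenyl on an aromatic nitrogen, the same change that separates compound 1 from compound 2. Because the earlier step of a 1.5-fold higher number from compound 1 to compound 2 (0.18 log units; within the scatter) stayed within the scatter, compound 4 is expected to show a step that the limit leaves unreadable from compound 3 to compound 4. Compound 4 is therefore estimated at 30000 nM, with a likely range from 15000 nM to 80000 nM, and most probably reported again only as a limit.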

Compound 4, half-maximal inhibitory concentration: 13900 nM
The estimate for compound 4 lay 2.2-fold (0.33 log units) above the measured number; measured number below the stated range.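

In this assay, putting 2-fluorophenyl in place of 4-methylphenyl on an aromatic nitrogen of the second core gives an at least 1.4-fold lower number from compound 3 to compound 4 (0.15 log units; that floor lies within the scatter). On these data alone, compound 3 is reported only as a limit of the assay, > 20000 nM, so the printed step is a floor and the true size of the step stays unknown. The data therefore show no clear gain or loss from this change on either core, but they do not show that it behaves alike on both: the same change on two cores in this assay, a 1.5-fold higher number (0.18 log units; within the scatter) from compound 1 to compound 2 and an at least 1.4-fold lower number (0.15 log units; that floor lies within the scatter) from compound 3 to compound 4; the limit leaves it open whether they differ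

The compounds shown carry only 4-methylphenyl or 2-fluorophenyl on that nitrogen, which leaves open how an amine, a carboxylic acid or a longer chain in the same place would read in this assay. Also open, as far as these compounds go, is how this same swap would read on a further core where neither value sits at a limit.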